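The compounds below may be only part of what the source reports. "The series", "measured", "known", "first", "only" and "open" are said of these compounds alone.

Compound 1 `CO/N=C/c1c(N)ncnc1Oc1ccc2cccnc2c1`: 2620 nM
Compound 2 `CNCCO/N=C/c1c(N)ncnc1Oc1ccc2[nH]c(C)cc2c1F`: 3010 nM
Compound 3 `CO/N=C/c1c(N)ncnc1Oc1ccc2[nH]cc(C)c2c1`: 385 nM

All three were tested in a functional assay on HCT-116 cells (Homo sapiens) for antiproliferative activity; a lower number here means a stronger inhibitor, a higher number a weaker inhibitor. Compound 2 has the highest number of the three; compound 1 sits within the scatter of it, so no order between those two can be read, while compound 3 lies beyond the scatter with a clearly lower number. Compound 4 `Cc1cc2c(F)c(Oc3ncnc(N)c3/C=N/OCC3CCCCC3)ccc2[nH]1` has not yet been measured. It differs from compound 2 in one place: cyclohexyl in place of (methylamino)methyl on a saturated chain carbon bound to an oxygen on an unsaturated carbon. No pair of measured compounds differs in this way, so the direction of the step rests on expectation alone rather than on a shown step. The expected step is a 2.0-fold lower number from compound 2 to compound 4 (0.30 log units; within the scatter), a modest move toward a lower number, close to the edge of the scatter. Compound 4 is accordingly estimated at 1500 nM, with a range from 300 nM to 8000 nM.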

Compound 4, half-maximal inhibitory concentration: 16100 nM
The estimate for compound 4 lay 11-fold (1.03 log units) below the measured number, outside the stated range (above it).
By their numbers in this assay, from the lowest: compound 3; then compounds 1 and 2 (each within the scatter of the next); then compound 4.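

In this assay, cyclohexyl in place of (methylamino)methyl on a saturated chain carbon bound to an oxygen on an unsaturated carbon gives a 5.3-fold higher number from compound 2 to compound 4 (0.73 log units; beyond the scatter), so what this place carries does matter. This single change both removes the amine nitrogen and adds a ring, and one pair cannot separate the two. No measurement at hand accounts for the step. Still open, on these data alone, is whether the ring or the lost nitrogen goes with the higher number. A piperidine ring at this place would bring the ring and an amine nitrogen together.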